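A few compounds are considered here, and "the series" means these few. Any claim that something is new, unique, unknown or untested is made for them only; others in the source may bear on it.

Compound 2 `Clc1ccc(-c2cc(-c3cccs3)nc(-c3cccs3)c2)o1` is the weaker of the two compounds measured in a functional assay on HeLa cells (Homo sapiens) for cytotoxicity, with a stated time of 3 days; a lower number here means a stronger inhibitor, a higher number a weaker inhibitor: compound 2 gives 55200 nM, the highest of the two numbers, while compound 1 `c1csc(-c2cc(-c3ccoc3)cc(-c3cccs3)n2)c1` gives 8620 nM. Going by the values given here, the one step recorded between them, a 6.4-fold higher number from compound 1 to compound 2 (0.81 log units; beyond the scatter), swaps one five-membered ring for another at a ring carbon of the shared core.

Compound 3 `Clc1ccc(-c2cc(-c3ccsc3)nc(-c3cccs3)c2)o1` is the next compound to be tested in this assay. It differs from compound 2 by thiophen-3-yl in place of thiophen-2-yl on an aromatic carbon; the two have the same atoms joined differently. Among the compounds with values here, no measured step concerns this particular exchange of one thiophenyl attachment for the other, so the only guide is that the single recorded step, a 6.4-fold higher number from compound 1 to compound 2 (0.81 log units; beyond the scatter), was of modest size for a change of a whole ring substituent. Moving the attachment point of a ring of identical composition is expected to produce a smaller effect than that, most likely none beyond the scatter, with no clear direction. Compound 3 is therefore expected to show a step of a 1.1-fold lower number from compound 2 to compound 3 (0.04 log units; within the scatter), giving an estimated value of 50000 nM, within a range from 18000 nM to 140000 nM.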

Compound 3, half-maximal inhibitory concentration: 43700 nM
For compound 3 the middle estimate is 1.1-fold (0.06 log units) above the measured one, and the stated range covers the measured number.
By their numbers in this assay, from the lowest: compound 1; then compounds 3 and 2 (each within the scatter of the next).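

In this assay, the exchange of thiophen-2-yl for thiophen-3-yl on the aromatic carbon next to the ring nitrogen gives a 1.3-fold lower number from compound 2 to compound 3 (0.10 log units; within the scatter) and is the first change shown at this position, since the earlier step concerned a different substituent, the one that is 5-chlorofuran-2-yl in compound 2. The two compounds have the same atoms joined differently, so with the 5-chlorofuran-2-yl group and the other thiophen-2-yl group held fixed, the point of attachment of this thiophene ring makes no difference that can be read in this measurement. Nothing among the data shown accounts for this result.

The compounds shown leave open whether the same exchange would also stay within the scatter with furan-3-yl in place of the 5-chlorofuran-2-yl group, as in compound 1, or at the remaining thiophen-2-yl group. They also leave open how this position responds to a substituent other than a thiophene ring, such as a phenyl ring, an amine, a carboxylic acid or a longer alkyl chain.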